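Cyclopentyl in Place of Hydrogen: Expected Lipophilicity

The source may report more compounds than this note shows. Statements on the series, on what has been measured and on what is new or still open speak of the compounds shown alone.

Of the compounds shown here, three sharing one core have been measured in a physicochemical assay for lipophilicity, using the shake flask method; on this read-out higher numbers stand for higher lipophilicity and lower numbers for lower lipophilicity. Compound 1 `CCO/N=C/c1c(N)ncnc1Oc1ccc(NC(=O)C2(C(=O)Nc3ccc(F)cc3)CC2)cc1F` gives 3.41. Compound 2 `Nc1ncnc(Oc2ccc(NC(=O)C3(C(=O)Nc4ccc(F)cc4)CC3)cc2F)c1/C=N/O` gives 2.62, the lowest of the three numbers. Compound 3 `Nc1ncnc(Oc2ccc(NC(=O)C3(C(=O)Nc4ccc(F)cc4)CC3)cc2F)c1/C=N/OCCCO` gives 2.67. Compound 4 `Nc1ncnc(Oc2ccc(NC(=O)C3(C(=O)Nc4ccc(F)cc4)CC3)cc2F)c1/C=N/OC1CCCC1` is not yet measured; it differs from compound 2 by cyclopentyl in place of hydrogen on an oxygen. Two measured steps involve the same oxygen: a number 0.79 log units lower from compound 1 to compound 2 (beyond the scatter) and a number 0.05 log units higher from compound 2 to compound 3 (within the scatter). Removing an ethyl group from that oxygen lowered the number modestly, while attaching a 3-hydroxypropyl group left it within the scatter. Cyclopentyl carries no hydroxy group, so a rise somewhat beyond the ethyl step is expected, a number 1.28 log units higher from compound 2 to compound 4 (beyond the scatter). Compound 4 is therefore estimated at 3.9, within 3.4 to 4.4.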

Compound 4, partition coefficient: 4.27
Beside the measured number, compound 4's estimate is 0.37 log units below it; measured number inside the range.
By their numbers in this assay, from the lowest: compounds 2 and 3 (each within the scatter of the next); then compound 1; then compound 4.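

On this oxygen, the largest change so far comes with cyclopentyl in place of hydrogen (a number 1.65 log units higher from compound 2 to compound 4 (beyond the scatter)) in this assay. Cyclopentyl in place of 3-hydroxypropyl moves the number almost as far (a number 1.60 log units higher from compound 3 to compound 4 (beyond the scatter)), and cyclopentyl in place of ethyl still shows a clear rise (a number 0.86 log units higher from compound 1 to compound 4 (beyond the scatter)), so the position responds strongly to which group it carries. No measurement here accounts for the size of these steps.

The compounds shown leave open whether the ring itself matters or only its carbon atoms. A pentyl chain on this oxygen would help separate the two, while an amine on the cyclopentyl ring would test how far one added group pulls the number back.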